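The source may hold more compounds than are shown below. What is called first, only, known or untested is meant among the compounds shown, and "the series" means these compounds.

Measured in a functional assay on A549 cells (Homo sapiens) for antiproliferative activity, read by MTT assay, with a stated time of 72 h (a lower number here means a stronger inhibitor, a higher number a weaker inhibitor), as follows:
- compound 1 `CCn1cc(C(=O)O)c(=O)c2cc(F)c(N3CCN(C(=N)NS(=O)(=O)c4ccc(C(F)(F)F)cc4)CC3)cc21` gives 71 nM here
- compound 2 `N=C(NS(=O)(=O)c1ccccc1Cl)N1CCN(c2cc3c(cc2F)c(=O)c(C(=O)O)cn3C2CC2)CC1` gives 71 nM here

Compound 2 stands level with compound 1 at the digits shown, so no order can be drawn between the two. The next compound to be read is compound 3 `N=C(NS(=O)(=O)c1ccc(C(F)(F)F)cc1)N1CCN(c2cc3c(cc2F)c(=O)c(C(=O)O)cn3C2CC2)CC1` which differs from compound 2 in one place: 4-(trifluoromethyl)phenyl in place of 2-chlorophenyl on a sulfonyl sulfur with the rest of the structure shared.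

Among the compounds with values here, the series holds no measured step between compounds that differ in one place, so nothing shows directly what this exchange does. In this assay no shift beyond the scatter is expected, in either direction. Within the data shown here, that expectation is weakly anchored: it rests on compound 2 at 71 nM as the starting point and on the absence of any measured spread so far. The expected change a 1.0-fold lower number from compound 2 to compound 3 (0.01 log units; within the scatter) therefore stays within the scatter. For compound 3 the estimated value is 70 nM with an expected range from 22 nM to 220 nM in this assay.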

Compound 3, half-maximal inhibitory concentration: 71 nM
For compound 3 the middle estimate is 1.0-fold (0.01 log units) below the measured one; the range from low to high includes it.
By their numbers in this assay, from the lowest: compounds 1, 2 and 3 (each within the scatter of the next).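

In this assay, within the data shown here, the exchange of 2-chlorophenyl for 4-(trifluoromethyl)phenyl on a sulfonyl sulfur gives no change at the digits printed from compound 2 to compound 3 (within the scatter), the first reading of a single exchange at this position, and here the two groups cannot be told apart. Among these compounds, the exchange of ethyl for cyclopropyl on an aromatic nitrogen gives no change at the digits printed from compound 1 to compound 3 (within the scatter), so this second position also shows no separation in this pair, with the 4-(trifluoromethyl)phenyl group held in common. Nothing available explains why either exchange leaves the reading level, and no cause can be assigned.

Neither step shows how far the sulfonyl position tolerates other groups, such as an unsubstituted phenyl, a 4-methoxyphenyl, a pyridyl ring or a plain methyl in place of the aryl ring. On these data alone, on the aromatic nitrogen, a longer chain such as propyl or butyl, or a bare hydrogen, remains open, as does whether either of these positions can move the reading beyond the scatter at all.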